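Bis-sulfonamide piperidine esters: a chain change at the sulfonamide nitrogen

This account rests on a few compounds, and the source may have more. Where it says the series, first, only, none or still open, it means among the compounds named here.

Measured compounds:
compound 1, `CCN(CC)S(=O)(=O)c1ccc(S(=O)(=O)N2CCC[C@@H](C(=O)N(C)C(C)C)C2)cc1`, 6200 nM;
compound 2, `CCOC(=O)[C@@H]1CCCN(S(=O)(=O)c2ccc(S(=O)(=O)N(CC)C(C)C)cc2)C1`, 1000 nM;
compound 3, `CCOC(=O)C1CCN(S(=O)(=O)c2ccc(S(=O)(=O)N(CC)CC)cc2)CC1`, 27200 nM.

In a functional assay on MIA PaCa-2 cells (Homo sapiens) for inhibition, read by MTT assay, with a stated time of 7 days (on this read-out higher numbers stand for weaker inhibition and lower numbers for stronger inhibition), compound 2 gives the lowest number of the three. Compound 1 sits beyond the scatter above it, and compound 3 lies furthest away, also beyond the scatter. The shared core carries two sulfonamides, and the compounds differ in their groups on the sulfonamide nitrogen and the piperidine ring.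

Compound 4, `CCCN(CC)S(=O)(=O)c1ccc(S(=O)(=O)N2CCC[C@@H](C(=O)OCC)C2)cc1`, is not yet measured. It differs from compound 2 by propyl in place of isopropyl on a sulfonamide nitrogen. The two have the same atoms, joined differently. Among the measured compounds shown here, no measured pair shows this change, so its effect is uncertain. Compound 4 is expected to show a step of a 1.5-fold higher number from compound 2 to compound 4 (0.18 log units; within the scatter) from compound 2, within the scatter. The estimate for compound 4 is 1500 nM, with a range from 500 nM to 4500 nM.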

Compound 4, half-maximal inhibitory concentration: 300 nM
Compound 4: the middle estimate sits 5.0-fold (0.70 log units) above what was measured; the whole stated range lies above it.
By their numbers in this assay, from the lowest: compound 4; then compound 2; then compound 1; then compound 3.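

In this assay, propyl in place of isopropyl on a sulfonamide nitrogen gives a 3.3-fold lower number from compound 2 to compound 4 (0.52 log units; beyond the scatter), so this position responds to how the same three carbons are joined. Among the compounds shown here, this is the first step here that isolates a single place, which the earlier compounds, differing in more than one place, could not show. Nothing measured here accounts for the step. On these data alone, whether a longer chain such as butyl on this nitrogen would give a lower or higher number stays open, as does whether the change holds with an amide in place of the ethyl ester.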